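Lengthening the Chain from Compound 3 to Compound 4

This account rests on a few compounds, and the source may have more. Where it says the series, first, only, none or still open, it means among the compounds named here.

Measured in an ADME assay on MRC5 cells (Homo sapiens) for inhibition, read by MTT assay, with a stated time of 72 h; a higher number here means a weaker inhibitor, a lower number a stronger inhibitor
- Compound 1 `O=C(OCCCCCCO)OCCc1ccc(O)c(O)c1` gives > 50000 nM (a limit of the assay, not a number)
- Compound 2 `CCCCCCCCOC(=O)OCCc1ccc(O)c(O)c1` gives 37900 nM
- Compound 3 `CCCCCCCCCCCCOC(=O)OCCc1ccc(O)c(O)c1` gives 12400 nM

Compound 3 has the lowest number of the three. Compound 4 `CCCCCCCCCCCCCCOC(=O)OCCc1ccc(O)c(O)c1` is still unmeasured and differs from it by ethyl in place of hydrogen on a saturated chain carbon, ten or more bonds along the chain from an oxygen next to a carbonyl group. For the measured compounds named here, the closest precedent, which added butyl in place of hydrogen on the chain, is a 3.1-fold lower number from compound 2 to compound 3 (0.49 log units; beyond the scatter). A second step points the same way but starts from a limit, an at least 4.0-fold lower number from compound 1 to compound 3 (0.60 log units; beyond the scatter). Ethyl is the smaller addition, so a smaller fall in this assay is expected, with a real chance of none beyond the scatter. The expected change is a 1.6-fold lower number from compound 3 to compound 4 (0.19 log units; within the scatter). For compound 4 the estimated value is 8000 nM, with an expected range of 3000 nM to 20000 nM.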

Compound 4, half-maximal inhibitory concentration: 9100 nM
Beside the measured number, compound 4's estimate is 1.1-fold (0.06 log units) below it; the measured number falls inside the stated range.
By their numbers in this assay, from the lowest: compounds 4 and 3 (each within the scatter of the next); then compound 2. At a limit, above all of these: compound 1.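

In this assay, ethyl in place of hydrogen on a saturated chain carbon gives a 1.4-fold lower number from compound 3 to compound 4 (0.13 log units; within the scatter), so here lengthening brings no clear change, unlike a 3.1-fold lower number from compound 2 to compound 3 (0.49 log units; beyond the scatter). Over the wider span, a 4.2-fold lower number from compound 2 to compound 4 (0.62 log units; beyond the scatter) still stands. Compound 1 carries a limit and not a number, which leaves an at least 5.4-fold lower number from compound 1 to compound 4 (0.73 log units; beyond the scatter) as a floor only. As far as these compounds go, whether a longer chain would bring any real fall remains open. So does the effect of an amine or a carboxylic acid on this chain.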